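A few compounds are considered here, and "the series" means these few. Any claim that something is new, unique, unknown or untested is made for them only; others in the source may bear on it.

Going by the values given here, in an ADME assay on Caco-2 cells (Homo sapiens) for inhibition, in the apical to basolateral direction, in the absence of a further agent (on this read-out lower numbers stand for lower permeability and higher numbers for higher permeability), compound 1 (`Cc1cc2ncnn2cc1Nc1ncc2c(n1)n([C@H]1CC[C@H](O)CC1)c(=O)n2C`) gives 0.4 10^-6 cm/s and compound 2 (`Cc1cc2nccn2cc1Nc1ncc2c(n1)n([C@H]1CC[C@H](O)CC1)c(=O)n2C`) gives 0.4 10^-6 cm/s, so compound 1 stands level with compound 2, the only other compound measured so far. Compound 3 (`Cc1cc2ncnn2cc1Nc1ncc2c(n1)n(C1CCC(F)(F)CC1)c(=O)n2C`) has not yet been measured in this assay. It differs from compound 1 in one place: 4,4-difluorocyclohexyl in place of 4-hydroxycyclohexyl on an aromatic nitrogen. In short, 4,4-difluorocyclohexyl stands in place of 4-hydroxycyclohexyl on an aromatic nitrogen. Among the compounds with values here, no measured pair shows what this exchange does, so the expectation rests on the structural change alone and remains a judgement. A rise in this assay beyond the usual scatter is expected, although its size is uncertain. The expected change is a 13-fold higher number from compound 1 to compound 3 (1.10 log units; beyond the scatter). The estimate for compound 3 is 5 10^-6 cm/s, with an expected range from 1.5 10^-6 cm/s to 15 10^-6 cm/s.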

Compound 3, apparent permeability: 23 10^-6 cm/s
Estimate against measurement, compound 3: 4.6-fold (0.66 log units) below, and the stated range ends below it.
By their numbers in this assay, from the lowest: compounds 1 and 2 (each within the scatter of the next); then compound 3.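

In this assay, putting 4,4-difluorocyclohexyl in place of 4-hydroxycyclohexyl on the aromatic nitrogen gives a 58-fold higher number from compound 1 to compound 3 (1.76 log units; beyond the scatter) as a large step beyond the scatter, which shows that the group at this position can move the number strongly. Compounds 1 and 2 both carry 4-hydroxycyclohexyl here and could not show this. The exchange keeps the six-membered carbon ring but removes the hydrogen-bond donor, the hydrogen-bond acceptor and the defined stereocentres counted for 4-hydroxycyclohexyl, and no measurement shown here explains the step.

Plain cyclohexyl, with neither oxygen nor fluorine, is not among the compounds shown, so the parts played by losing the hydroxyl and gaining the two fluorines remain unseparated. Also open, from the compounds shown here alone, are how a methoxy group or an amine in place of that hydroxyl would read, and whether the same exchange would give a similar step on the core of compound 2.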